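Series notes: metabolic stability from compound 2 to compound 3

The source may report more compounds than this note shows. Statements on the series, on what has been measured and on what is new or still open speak of the compounds shown alone.

Measured so far:
compound 1 `O=c1nc(N2CCN(CC3CCCCC3)CC2)sc2c([N+](=O)[O-])cc(C(F)(F)F)cc12` — 58.7%
compound 2 `CN(Cc1ccc2c(c1)OCCO2)c1cc(=O)c2cc(C(F)(F)F)cc([N+](=O)[O-])c2s1` — 44.9%

In an ADME assay on microsomes from liver (Homo sapiens) for metabolic stability, read by LC-MS, using NADPH, with a stated time of 30 min, tested at 1 uM (a higher number here means that more of the compound is left, a lower number that less of the compound is left), compound 2 gives 44.9%, the lowest of the two numbers. The nearest, compound 1, gives 58.7%, a value that lies beyond the scatter above compound 2.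

Compound 3 `CN(Cc1ccccc1)c1cc(=O)c2cc(C(F)(F)F)cc([N+](=O)[O-])c2s1` is not yet measured. It differs from compound 2 by phenyl in place of 2,3-dihydro-1,4-benzodioxin-6-yl on a saturated chain carbon bound to a nitrogen on an aromatic ring. Within the data shown here, no step between measured compounds carries this change, so nothing shows its size. In this assay the step from compound 2 to compound 3 is expected to be small, not beyond the scatter, in either direction. Compound 3 is estimated at 48%, with a range from 30% to 66%. The expected step is a number 3.1 percentage points higher from compound 2 to compound 3 (within the scatter).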

Compound 3, percent of the compound remaining: 11.6%
Compound 3: middle estimate off by 36.4 percentage points, on the high side; the whole stated range lies above it.
By their numbers in this assay, from the lowest: compound 3; then compound 2; then compound 1.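

In this assay, the group on a saturated chain carbon bound to a nitrogen on an aromatic ring proves decisive for the read-out: phenyl in place of 2,3-dihydro-1,4-benzodioxin-6-yl gives a number 33.3 percentage points lower from compound 2 to compound 3 (beyond the scatter). Among these compounds, this is the first pair that differs in one place, so it is the first to show the size of a change here. Nothing available accounts for the step.

Still open, from the compounds shown here alone, is how a methoxy group or a carboxylic acid on the phenyl would read. Going by these compounds, whether the step carries over to the core of compound 1 also remains open.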